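Swapping the dihalophenyl ring in a cytotoxic core

This account rests on a few compounds, and the source may have more. Where it says the series, first, only, none or still open, it means among the compounds named here.

Measured so far:
Compound 1 `C=CCn1c(=O)/c(=C\c2ccccc2Cl)[nH]c(=O)/c1=C\c1ccccc1OC`: 6400 nM
Compound 2 `C=CCn1c(=O)/c(=C\c2cccc(Cl)c2Cl)[nH]c(=O)/c1=C\c1ccccc1OC`: 1200 nM

Within the data shown here, in a functional assay on Huh-7 cells (Homo sapiens) for cytotoxicity, read by CCK-8 assay, with a stated time of 72 h (a lower number here means a stronger inhibitor, a higher number a weaker inhibitor), compound 2 stands lowest of the two numbers; its nearest neighbour is compound 1, and the step of a 5.3-fold lower number from compound 1 to compound 2 (0.73 log units; beyond the scatter) is the only measured change in this set. Compound 3 `C=CCn1c(=O)/c(=C\c2cc(Br)ccc2F)[nH]c(=O)/c1=C\c1ccccc1OC` has not been measured yet. It differs from compound 2 in one place: 5-bromo-2-fluorophenyl in place of 2,3-dichlorophenyl on a double-bonded chain carbon bound to an aromatic carbon. Among the measured compounds shown here, no measured step covers this exchange of one halogenated ring for another. For the measured compounds named here, the one known step shows that halogen substitution on that ring can move this assay by a modest amount, so a change of similar size in either direction seems plausible, with no strong reason to expect compound 3 to beat compound 2. The estimate for compound 3 is therefore 3000 nM, within 1000 nM to 9000 nM, corresponding to an expected step of a 2.5-fold higher number from compound 2 to compound 3 (0.40 log units; beyond the scatter).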

Compound 3, half-maximal inhibitory concentration: "not active" (no number reported)
No number was reported for compound 3, and the estimate cannot be compared.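

Among these compounds, compound 3 is reported in this assay only as "not active", without a number, so no step from compound 2 to compound 3 can be read. Nothing shown here explains this result. The compounds shown leave open how far 5-bromo-2-fluorophenyl in place of 2,3-dichlorophenyl shifts the number.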